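Dropping a Methoxy Group: the Same Change on Two Cores

The compounds below may be only part of what the source reports. "The series", "measured", "known", "first", "only" and "open" are said of these compounds alone.

Of the compounds shown here, three have so far been tested in a functional assay on U-87MG ATCC cells for antiproliferative activity against U-87 MG (Homo sapiens), read by MTT assay, with a stated time of 48 h, tested at 100 uM; a lower number here means a stronger effect, a higher number a weaker effect of the compound at the concentration tested. Compound 1 `COc1ccc(-c2nc(C)c(C(=O)CSc3nc(-c4cccc(OC)c4)c(C#N)c(=O)[nH]3)s2)cc1` gives 12.4% in this assay, and compound 2 `COc1cccc(-c2nc(SCC(=O)c3sc(-c4ccccc4)nc3C)[nH]c(=O)c2C#N)c1` gives 21.8%. The two differ in one place only, (hydrogen in place of methoxy on an aromatic carbon), and in this assay the step of a number 9.4 percentage points higher from compound 1 to compound 2 (within the scatter). Compound 3 `COc1ccc(-c2nc(SCC(=O)c3sc(-c4ccc(Cl)cc4)nc3C)nc(N)c2C#N)cc1` gives 0.79%, the lowest of the three numbers, with both compound 1 and compound 2 standing beyond the scatter above it. Compound 3 differs from compound 1 in more than one place, so the difference between the two cores is not broken down here.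

Compound 4 `Cc1nc(-c2ccc(Cl)cc2)sc1C(=O)CSc1nc(N)c(C#N)c(-c2ccccc2)n1` has not yet been measured. It differs from compound 3 by the same change already seen between compound 1 and compound 2, namely (hydrogen in place of methoxy on an aromatic carbon). Since that change gave only a small step, the reader is led to expect a step of similar size, a number 7.2 percentage points higher from compound 3 to compound 4 (within the scatter), from compound 3 to compound 4, resting on the step of a number 9.4 percentage points higher from compound 1 to compound 2 (within the scatter) and on the low value of compound 3. Compound 4 is therefore estimated at 8% in this assay, between 0.5% and 24%.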

Compound 4, a percentage reported as activity, at one concentration (the size of the read-out at that concentration, not a potency): 4.59%
The estimate for compound 4 lay 3.4 percentage points above the measured number, and the stated range covers the measured number.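

Removing the methoxy group on the core of compound 3, 4-methoxyphenyl to phenyl, gives a small step in this assay, a number 3.8 percentage points higher from compound 3 to compound 4 (within the scatter), and the two pairs can be read as showing the same small result on both cores: the same change on two cores in this assay, a number 9.4 percentage points higher (within the scatter) from compound 1 to compound 2 and a number 3.8 percentage points higher (within the scatter) from compound 3 to compound 4, 5.6 percentage points apart, within the scatter of two such steps

So in these two pairs, the loss of a methoxy group moves the read-out by no more than the usual scatter, whichever core carries it. Among the compounds shown here, this does not establish that the change is without effect across the series, as it rests on only two pairs, the methoxy group leaves a different ring of the molecule in each pair, and a read-out at one concentration is not a potency.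

The compounds shown leave open how a hydroxyl group, an amine or a longer alkoxy chain in place of the methoxy group would read in this assay. They also leave open whether the same small step would appear on a third core.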